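Vero cytotoxicity: step from compound 2 to compound 3

The source may report more compounds than this note shows. Statements on the series, on what has been measured and on what is new or still open speak of the compounds shown alone.

Compound 2 `COC(=O)c1cc(-c2cccc(NC(=O)c3ccc(/C=C/C(=O)c4cccc(OC)c4)cc3)c2)on1` gives in an ADME assay on Vero cells (Chlorocebus sabaeus) for cytotoxicity, read by MTT assay, with a stated time of 72 h; a higher number here means that more compound is tolerated, a lower number that less compound is tolerated > 100 ug/mL, which is a limit of the assay rather than a number. Compound 1 `COC(=O)c1cc(-c2cccc(NC(=O)c3ccc(/C=C/C(=O)c4ccccc4OC)cc3)c2)on1` gives in this assay > 40 ug/mL, likewise a limit. The step that the two limits leave unreadable from compound 1 to compound 2 cannot be sized; the limit of > 100 ug/mL in this assay, at which 1 of the 2 values shown sits, and the limit of > 40 ug/mL in this assay, at which 1 of the 2 values shown sits, show only where the two values sit. Compound 3 `COC(=O)c1cc(-c2cccc(NC(=O)c3ccc(/C=C/C(=O)c4ccc(OC)c([N+](=O)[O-])c4)cc3)c2)on1` differs from compound 2 by 4-methoxy-3-nitrophenyl in place of 3-methoxyphenyl on a carbonyl carbon. Going by the values given here, no measured step touches this change, and the limit of compound 2 leaves no direction to read. Compound 3 is expected near the same limit, estimated at 100 ug/mL (range 40 ug/mL to 200 ug/mL). The expected step of a number no higher from compound 2 to compound 3 (the limit leaves the size open) is not anticipated to exceed the scatter.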

Compound 3, half-maximal cytotoxic concentration: > 40 ug/mL
Compound 3: no number, only a limit; the forecaster's own chance of this, stated with the estimate: 65%; the middle value lies beyond the limit too.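

In this assay compound 3 gives > 40 ug/mL, a limit of the assay and not a number. Going by these compounds alone, compound 2 gives > 100 ug/mL, also a limit, so no step among compound 1, compound 2 and compound 3 can be read. Where the actual cytotoxic concentrations of these compounds lie, and whether the aryl changes on the carbonyl carbon shift them, stays open.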